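A few compounds are considered here, and "the series" means these few. Any claim that something is new, unique, unknown or untested is made for them only; others in the source may bear on it.

Two compounds share a common core and differ only in the ring carried on an aromatic nitrogen of a six-membered aromatic ring with 2 nitrogen. In a functional assay on U-87MG ATCC cells (Homo sapiens) for inhibition, read by MTT assay, with a stated time of 72 h (on this read-out lower numbers stand for stronger inhibition and higher numbers for weaker inhibition), compound 1 `COc1cc2c(Oc3ccc(NC(=O)c4nn(-c5ccccc5C)c(=O)cc4C)cc3F)ccnc2cc1OCCCN1CCCCC1` gives 2500 nM, while compound 2 `COc1cc2c(Oc3ccc(NC(=O)c4nn(-c5ccccc5OC(F)(F)F)c(=O)cc4C)cc3F)ccnc2cc1OCCCN1CCCCC1` gives 1300 nM. The gap between them, a 1.9-fold lower number from compound 1 to compound 2 (0.28 log units; within the scatter), lies within the scatter, so compound 2 cannot be set apart from compound 1 on these numbers.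

Compound 3 `COc1cc2c(Oc3ccc(NC(=O)c4nn(-c5ccc(Cl)cc5)c(=O)cc4C)cc3F)ccnc2cc1OCCCN1CCCCC1` carries the change (4-chlorophenyl in place of 2-(trifluoromethoxy)phenyl on an aromatic nitrogen). Among the compounds with values here, the only measured step on this ring, from compound 1 to compound 2, swapped one small group for another at the same spot and stayed within the scatter; no measured step moves a substituent from one place on that ring to another. The expected step in this assay is therefore a 1.4-fold higher number from compound 2 to compound 3 (0.14 log units; within the scatter), no more than the scatter. Compound 3 is estimated at 1800 nM, within 600 nM to 6000 nM.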

Compound 3, half-maximal inhibitory concentration: 1400 nM
Beside the measured number, compound 3's estimate is 1.3-fold (0.11 log units) above it; the measured number falls inside the stated range.
By their numbers in this assay, from the lowest: compounds 2, 3 and 1 (each within the scatter of the next).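

Within the data shown here, this is the first step here that changes where the substituent sits on the phenyl ring as well as which substituent it is. In this assay, 4-chlorophenyl in place of 2-(trifluoromethoxy)phenyl gives a 1.1-fold higher number from compound 2 to compound 3 (0.03 log units; within the scatter), and 4-chlorophenyl in place of 2-methylphenyl gives a 1.8-fold lower number from compound 1 to compound 3 (0.25 log units; within the scatter), so compound 3 cannot be told apart from either neighbour. At this position, then, these three substituted phenyl rings give numbers that cannot be separated, even with the substituent in a different place.

Going by these compounds, each of these steps changes the group and its place together, so the effect of place alone stays unknown, as does whether an amine or a carboxylic acid on this ring would give a step beyond the scatter. No supporting data are available to explain why the three numbers sit so close.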